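A few compounds are considered here, and "the series" means these few. Any claim that something is new, unique, unknown or untested is made for them only; others in the source may bear on it.

Measured so far:
- compound 1 `Nc1scc(CN2CCN(c3ccc(Cl)cc3F)CC2)c1C(=O)c1ccc(Cl)cc1` gives -81% in a functional assay on CHO cells with adenosine receptor A1 (Homo sapiens) as the target, read by cAMP accumulation and immunoassay, with a stated time of 6 min, tested at 10 uM; a higher number here means a weaker effect of the compound at the concentration tested, a lower number a stronger effect
- compound 2 `Nc1scc(CN2CCN(c3c(F)cccc3F)CC2)c1C(=O)c1ccc(Cl)cc1` gives -80% in this assay
- compound 3 `Nc1scc(CN2CCN(c3cccc(F)c3F)CC2)c1C(=O)c1ccc(Cl)cc1` gives -79% in this assay

Compound 3 carries the highest of the three numbers, but its nearest neighbour is compound 2 a number 1 percentage points higher from compound 2 to compound 3 (within the scatter), and compound 1 lies only a little further a number 2 percentage points higher from compound 1 to compound 3 (within the scatter); the three values cannot be told apart. The same holds for a number 1 percentage points higher from compound 1 to compound 2 (within the scatter).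

Compound 4 `Nc1scc(CN2CCN(c3c(F)cc(F)cc3F)CC2)c1C(=O)c1ccc(Cl)cc1` is the next case. The change: 2,4,6-trifluorophenyl in place of 2,3-difluorophenyl on an amine nitrogen in a ring

All three measured steps exchange one fluorinated or chlorofluorinated phenyl for another on the same ring nitrogen, and none of them moves the number beyond the scatter. The present change is of the same kind, so for compound 4 no step beyond the scatter is expected in this assay, that is no change at the digits printed from compound 3 to compound 4 (within the scatter). The estimate for compound 4 is therefore -79%, between -89% and -69%.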

Compound 4, a percentage reported as activity, at one concentration (the size of the read-out at that concentration, not a potency): -78%
Compound 4: middle estimate off by 1 percentage points, on the low side, within the range that was stated.
By their numbers in this assay, from the lowest: compounds 1, 2, 3 and 4 (each within the scatter of the next).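

Adding fluoro in place of hydrogen on an aromatic carbon of the 2,6-difluorophenyl group gives a number 2 percentage points higher from compound 2 to compound 4 (within the scatter) in this assay and is the first single-atom change at this position. The 2,4,6-trifluorophenyl group also cannot be told apart from the other aryl groups, with a number 1 percentage points higher from compound 3 to compound 4 (within the scatter) and a number 3 percentage points higher from compound 1 to compound 4 (within the scatter) as well. No evidence on hand bears on this result.

From the compounds shown here alone, whether a phenyl without halogen, a methoxyphenyl or a pyridyl group on this ring nitrogen would hold the read-out remains open. Potency differences among the four compounds also remain open, as a single concentration does not show them.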